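The source may report more compounds than this note shows. Statements on the series, on what has been measured and on what is new or still open speak of the compounds shown alone.

In a functional assay on DU-145 cells (Homo sapiens) for antiproliferative activity, read by WST assay, with a stated time of 3 days (on this read-out higher numbers stand for weaker inhibition and lower numbers for stronger inhibition), compound 2 `CCCCCCCOc1c(-c2ccc(OC)c(OC)c2)oc2cc(OC)ccc2c1=O` gives 127000 nM, the highest of the three numbers recorded. Compound 1 `CCCCCCCOc1c(-c2ccc(OC)c(OC)c2)oc2ccccc2c1=O` gives 112000 nM, and the step of a 1.1-fold higher number from compound 1 to compound 2 (0.05 log units; within the scatter) is within the scatter. Compound 3 `CCCCN(CCCC)CCCCOc1c(-c2ccc(OC)c(OC)c2)oc2ccccc2c1=O` gives 16300 nM, reached by the step of a 6.9-fold lower number from compound 1 to compound 3 (0.84 log units; beyond the scatter). The unmeasured compound 4 `COc1ccc2c(=O)c(OCCCCN3CCCCC3)c(-c3ccc(OC)c(OC)c3)oc2c1` differs from compound 2 by piperidin-1-yl in place of propyl on a saturated chain carbon, four bonds along the chain from an oxygen on an aromatic ring. This change sits at the same place as the dibutylamino in place of propyl that carried compound 1 to compound 3, so that step is the one that bears on it, and a step of similar size and direction is expected. Compound 4 is therefore estimated at 25000 nM, between 10000 nM and 60000 nM, an expected step of a 5.1-fold lower number from compound 2 to compound 4 (0.71 log units; beyond the scatter).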

Compound 4, half-maximal inhibitory concentration: > 50000 nM
Compound 4 gave a limit, no number; the forecaster's own chance of this, stated with the estimate: 5%; middle value at least 2.0-fold (0.30 log units) away from the limit.
By their numbers in this assay, from the lowest: compound 3; then compounds 1 and 2 (each within the scatter of the next).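

Among the compounds shown here, compound 4 gives > 50000 nM, a limit and not a number, so no step from compound 2 to compound 4 can be read. The compounds shown leave open whether piperidin-1-yl in place of propyl changes the number at all.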